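The source may report more compounds than this note shows. Statements on the series, on what has been measured and on what is new or still open speak of the compounds shown alone.

Measured so far in an assay on BTI cells for inhibition of Amine oxidase [flavin-containing] B (Homo sapiens), read by fluorescence, with a stated time of 20 min, tested at 1 uM; a lower number here means less inhibition, a higher number more inhibition at the concentration tested (going by the name of the read-out):
compound 1, `CC1(C)COc2ccccc2C1O`, gives 8%
compound 2, `C#CCNC1c2ccccc2OCC1(C)C`, gives 11.6%

Compound 1 stands lowest of the two numbers; the nearest is compound 2, and the step of a number 3.6 percentage points higher from compound 1 to compound 2 (within the scatter) lies within the scatter, so the two cannot be ordered against each other. The unmeasured compound 3, `COc1cccc2c1C(O)C(C)(C)CO2`, keeps the core of compound 1 and differs from it only at the aromatic ring: methoxy in place of hydrogen on an aromatic carbon. Within the data shown here, no measured step touches an aromatic carbon; the single step seen so far, a number 3.6 percentage points higher from compound 1 to compound 2 (within the scatter), concerns a saturated ring carbon and was itself within the scatter, so it gives no lead on the direction a methoxy might take. Among the measured compounds shown here, both measured numbers sit low, and nothing so far shows a small change to the core moving this assay far. The expectation for the step from compound 1 to compound 3 is therefore none beyond the scatter, a number 2 percentage points higher from compound 1 to compound 3 (within the scatter). Compound 3 is expected to give 10%, with a range from 0% to 25%.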

Compound 3, a percentage reported as inhibition, at one concentration (the size of the read-out at that concentration, not a potency): 5.3%
Beside the measured number, compound 3's estimate is 4.7 percentage points above it; low and high end bracket the measured number.
By their numbers in this assay, from the lowest: compounds 3, 1 and 2 (each within the scatter of the next).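

In this assay, among these compounds, the step of a number 2.7 percentage points lower from compound 1 to compound 3 (within the scatter) is the first to touch the aromatic ring, as the earlier step concerned a saturated ring carbon. At this position, on an aromatic carbon of the six-membered aromatic ring, ortho to a fused ring and meta to a fused ring, methoxy in place of hydrogen has no effect that can be separated from the scatter, so the change adds a second substitution site without yet showing that the site matters to this read-out. Nothing measured here explains the result or bears on it.

As far as these compounds go, what chlorine, a carboxylic acid or a longer alkoxy chain would do on this aromatic carbon remains open, as does whether any group there can move the number beyond the scatter. Also open, from the compounds shown here alone, is whether methoxy at this position would read the same with propargylamino in place of hydroxy on the saturated ring carbon, a pairing that would join the two single changes seen so far.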